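The source may report more compounds than this note shows. Statements on the series, on what has been measured and on what is new or still open speak of the compounds shown alone.

In a functional assay (strain AB) with Danio rerio as the target, read by microscopy, with a stated time of 1 h (on this read-out lower numbers stand for an effect already at smaller amounts and higher numbers for an effect only at larger amounts of compound), compound 1 `CC(C)CN1CCc2c(sc(NC(=O)Nc3ccc(Cl)cc3)c2C(N)=O)C1` gives 4510 nM, and compound 2 `CCN1CCc2c(sc(NC(=O)Nc3ccc(Cl)cc3)c2C(N)=O)C1` gives 3120 nM. The step of a 1.4-fold lower number from compound 1 to compound 2 (0.16 log units; within the scatter) changes little. Compound 3 `CCN1CCc2c(sc(NC(=O)Nc3ccc(Cl)cc3)c2C(=O)N2CCOCC2)C1` reaches only a limit of the assay in this assay, > 25000 nM. The step of an at least 8.0-fold higher number from compound 2 to compound 3 (0.90 log units; beyond the scatter) is therefore a loss, with the value of compound 3 sitting at the limit of > 25000 nM in this assay, at which 1 of the 3 values shown sits. Among the numbers shown, compound 2 holds the lowest one, with compound 1 nearest and within the scatter, and compound 3 known only as a limit.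

Compound 4 `CCN1CCc2c(sc(NC(=O)Nc3cccc(C)c3)c2C(N)=O)C1` differs from compound 2 by 3-methylphenyl in place of 4-chlorophenyl on an amide-type nitrogen. Neither measured step touches this part of the molecule: the step from compound 1 to compound 2 concerns the substituent on the ring amine, and the step from compound 2 to compound 3 concerns the carboxamide. No shown step therefore bears directly on this change, and no step beyond the scatter is expected in this assay; the account expects a 1.4-fold higher number from compound 2 to compound 4 (0.16 log units; within the scatter). For compound 4 the estimated value in this assay is 4500 nM, with an expected range from 1500 nM to 15000 nM.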

Compound 4, half-maximal effective concentration: 13000 nM
Compound 4: the middle estimate sits 2.9-fold (0.46 log units) below what was measured; low and high end bracket the measured number.
By their numbers in this assay, from the lowest: compounds 2 and 1 (each within the scatter of the next); then compound 4. At a limit, above all of these: compound 3.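

In this assay, the aryl group on the amide-type nitrogen proves to matter, with 3-methylphenyl in place of 4-chlorophenyl giving a 4.2-fold higher number from compound 2 to compound 4 (0.62 log units; beyond the scatter). This is the first change shown at this place, and it goes beyond the scatter, whereas the change on the ring amine, a 1.4-fold lower number from compound 1 to compound 2 (0.16 log units; within the scatter), stayed within it. Nothing in the data at hand accounts for the size of this step.

The change removes the chlorine, adds a methyl and moves the substituent on the ring all at once, so the compounds shown leave open which of these carries the difference. A 3-chlorophenyl or a 4-methylphenyl group on the same nitrogen would separate these contributions, and a plain phenyl group would show what the ring gives without any substituent.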